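The compounds below may be only part of what the source reports. "The series", "measured", "known", "first", "only" and "open" are said of these compounds alone.

Measured so far in an assay on L cells for inhibition of Protein-serine O-palmitoleoyltransferase porcupine (Mus musculus), read by reporter gene assay, with a stated time of 24 h; on this read-out lower numbers stand for an effect already at smaller amounts and higher numbers for an effect only at larger amounts of compound:

Compound 1 `COc1ccccc1-n1c(SCC(=O)Nc2nc3ccc(Cl)cc3s2)nc2c(c1=O)SCC2` gives 50 nM in this assay.
Compound 2 `COc1ccc2nc(NC(=O)CSc3nc4c(c(=O)n3-c3ccccc3OC)SCC4)sc2c1` gives 50 nM in this assay.

Compound 2 stands level with compound 1 at the digits shown: the step of no change at the digits printed from compound 1 to compound 2 (within the scatter) lies within the scatter, although it exchanges a chloro group for a methoxy group on an aromatic carbon of the benzothiazole part of the shared core.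

Compound 3 `COc1ccccc1-n1c(SCC(=O)Nc2nc3ccc(C)cc3s2)nc2c(c1=O)SCC2` differs from compound 2 by methyl in place of methoxy on an aromatic carbon. For the measured compounds named here, the only measured step that bears on this change is the one from compound 1 to compound 2, which altered the same kind of substituent, also on an aromatic carbon, and produced no change beyond the scatter. On that basis the step of no change at the digits printed from compound 2 to compound 3 (within the scatter) is expected to stay within the scatter as well, with no direction favoured. Compound 3 is therefore estimated at 50 nM in this assay, with a range from 25 nM to 100 nM.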

Compound 3, half-maximal effective concentration: 25 nM
The estimate for compound 3 lay 2.0-fold (0.30 log units) above the measured number, within the range that was stated.
By their numbers in this assay, from the lowest: compounds 3, 1 and 2 (each within the scatter of the next).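

In this assay, the change from 6-methoxy-1,3-benzothiazol-2-yl to 6-methyl-1,3-benzothiazol-2-yl gives a 2.0-fold lower number from compound 2 to compound 3 (0.30 log units; within the scatter), and methyl in place of chloro at the same place gives a 2.0-fold lower number from compound 1 to compound 3 (0.30 log units; within the scatter). This place has now carried chloro, methoxy and methyl with all three compounds within the scatter of one another, and the hydrogen-bond acceptor counted for methoxy can leave without a step beyond the scatter. Nothing available explains these numbers.

The compounds shown leave open whether an amine, a carboxylic acid or a longer chain at this place would also stay within the scatter. The rest of the structure is the same in all three compounds, so they say nothing about how changes elsewhere would read.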